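The source may hold more compounds than are shown below. What is called first, only, known or untested is meant among the compounds shown, and "the series" means these compounds.

Working notes on the series. Compound 1 `CC(C)COc1cccc(-c2ccc(C(=O)N(Cc3cccc(OCCCCCC(=O)O)c3)C(C)C)cc2)c1`, compound 2 `Cc1nnc(-c2cccc(-c3ccc(C(=O)N(Cc4cccc(OCCCCCC(=O)O)c4)C(C)C)cc3)c2)o1` and compound 3 `CCOC(=O)CCCCCOc1cccc(CN(C(=O)c2ccc(-c3cccc(-c4nnc(C)o4)c3)cc2)C(C)C)c1` share one core and have each been run in an ADME assay on HEK293 cells (Homo sapiens) for cytotoxicity, read by CellTiter-Glo and resazurin assay, with a stated time of 72 h; a lower number here means that less compound is needed, a higher number that more compound is needed for the effect. In this assay compound 1 gives only a limit of the assay, > 26000 nM. Compound 2 likewise stands at a limit, > 26000 nM. Compound 3 too returns a limit, > 26000 nM. For the measured compounds named here, because of the limit of > 26000 nM in this assay, at which 3 of the 3 values shown sit, the two measured steps, a step that the two limits leave unreadable from compound 1 to compound 2 and a step that the two limits leave unreadable from compound 2 to compound 3, cannot be sized; they show only that neither change brought the read-out into the measurable range.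

The unmeasured compound 4 `CCOC(=O)CCCCCOc1cccc(CN(C(=O)c2ccc(-c3cccc([N+](=O)[O-])c3)cc2)C(C)C)c1` differs from compound 3 by nitro in place of 5-methyl-1,3,4-oxadiazol-2-yl on an aromatic carbon. Going by the values given here, no measured step bears on this change directly; the two steps seen, isobutoxy to 5-methyl-1,3,4-oxadiazol-2-yl and hydrogen to ethyl, both left the value at a limit and give no size to build on. The expectation is therefore a step of no more than the scatter, a step that the limit leaves unreadable from compound 3 to compound 4. Compound 4 is expected to remain at or around the limit in this assay. Compound 4 is estimated at 30000 nM, with a range from 12000 nM to 80000 nM, and the most likely outcome is that only a limit is reported again.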

Compound 4, half-maximal effective concentration: > 26000 nM
Compound 4 ended at the assay's limit; the forecaster's own chance of this, stated with the estimate: 80%; the middle value is on the limit's open side.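

The step from compound 3 to compound 4 cannot be read, because compound 4 also stands at a limit, as compound 3 does: the limit of > 26000 nM in this assay, at which 4 of the 4 values shown sit.

The compounds shown leave open whether any change on the shared core would bring the read-out in this assay into the measurable range, and how large any of these steps really is.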